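Para substituent on the aryl ring of the shared core

The source may report more compounds than this note shows. Statements on the series, on what has been measured and on what is new or still open speak of the compounds shown alone.

Compound 1 `CC(=O)N1N=C(c2ccc(C)cc2)CC1c1ccc(C(=O)OC(C)Cn2c([N+](=O)[O-])cnc2C)cc1` carries a methyl on that ring; in a functional assay on B16-F10 cells (Mus musculus) for antiproliferative activity, read by MTT assay, with a stated time of 12 h (a lower number here means a stronger inhibitor, a higher number a weaker inhibitor), compound 1 gives only a limit, > 100000 nM. Compound 2 `CC(=O)N1N=C(c2ccc(Cl)cc2)CC1c1ccc(C(=O)OC(C)Cn2c([N+](=O)[O-])cnc2C)cc1` gives 22200 nM in this assay. Compound 3 `COc1ccc(C2=NN(C(C)=O)C(c3ccc(C(=O)OC(C)Cn4c([N+](=O)[O-])cnc4C)cc3)C2)cc1` gives 40600 nM in this assay, with the steps of an at least 2.4-fold lower number from compound 1 to compound 3 (0.39 log units; beyond the scatter) and a 1.8-fold higher number from compound 2 to compound 3 (0.26 log units; within the scatter), so compound 3 and compound 2 are not separable here. Compound 4 `CC(=O)N1N=C(c2ccc([N+](=O)[O-])cc2)CC1c1ccc(C(=O)OC(C)Cn2c([N+](=O)[O-])cnc2C)cc1` differs by nitro in place of methoxy on an aromatic carbon. Only the two steps ending at compound 3 bear on this change; both concern the same position, yet neither gives a direction for a nitro group. A step of modest size at most is therefore expected, a 1.6-fold lower number from compound 3 to compound 4 (0.21 log units; within the scatter). For compound 4 an estimate of 25000 nM in this assay is made, with a range from 8000 nM to 80000 nM.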

Compound 4, half-maximal inhibitory concentration: 12200 nM
Compound 4: middle estimate off by 2.0-fold (0.31 log units), on the high side; low and high end bracket the measured number.
By their numbers in this assay, from the lowest: compounds 4, 2 and 3 (each within the scatter of the next, the first and the last beyond it). At a limit, above all of these: compound 1.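

Nitro on this aromatic carbon is the first change at this position to separate from methoxy in this assay, a 3.3-fold lower number from compound 3 to compound 4 (0.52 log units; beyond the scatter), whereas chloro and methoxy could not be told apart. Nitro and chloro cannot be told apart either, a 1.8-fold lower number from compound 2 to compound 4 (0.26 log units; within the scatter). The step of an at least 8.1-fold lower number from compound 1 to compound 4 (0.91 log units; beyond the scatter) starts from a limit: the limit of > 100000 nM in this assay, at which 1 of the 4 values shown sits.

Going by these compounds, what remains open is how an amine or a carboxylic acid on this aromatic carbon would read in this assay. Also open, on these data alone, is whether the methyl compound has any measurable value.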